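Methoxy in Place of Fluoro on the Shared Core

A few compounds are considered here, and "the series" means these few. Any claim that something is new, unique, unknown or untested is made for them only; others in the source may bear on it.

Compound 1 (`Cc1cc(NC(=O)Nc2ccc(F)cc2)c2ccccc2n1`) in an ADME assay on BJ cells (Homo sapiens) for cytotoxicity, with a stated time of 72 h (a higher number here means that more compound is needed for the effect, a lower number that less compound is needed), gives > 25000 nM, which is a limit of the assay and not a number. Compound 1 therefore sits at the limit of > 25000 nM in this assay, at which 1 of the 2 values shown sits. Compound 2 (`Cc1cc(NC(=O)Nc2ccc(F)cc2F)c2ccccc2n1`) gives 20000 nM in this assay. For the measured compounds named here, the only measured step, an at least 1.2-fold lower number from compound 1 to compound 2 (0.09 log units; that floor lies within the scatter), is the sole guide here. Compound 3 (`COc1ccc(NC(=O)Nc2cc(C)nc3ccccc23)cc1`) differs from compound 1 by methoxy in place of fluoro on an aromatic carbon. Because an at least 1.2-fold lower number from compound 1 to compound 2 (0.09 log units; that floor lies within the scatter) stayed within the scatter, compound 3 is expected to show no step beyond the scatter, namely a number no higher from compound 1 to compound 3 (the limit leaves the size open). The estimate for compound 3 in this assay is 25000 nM, with a range from 12000 nM to 50000 nM.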

Compound 3, half-maximal effective concentration: > 25000 nM
Compound 3 ended at the assay's limit (the forecaster's own chance of this, stated with the estimate: 60%); the middle value sits exactly at the limit.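

In this assay, for the compounds shown here, compound 1 and compound 3 both stand at a limit of the assay, so no step between them can be read. The compounds shown leave open whether methoxy in place of fluoro changes the number at all.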